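The source may hold more compounds than are shown below. What is called first, only, known or untested is meant among the compounds shown, and "the series" means these compounds.

Of the compounds shown here, three of one shared core have been measured. Compound 1, of structure `CNC(=O)CSc1nc2ccc(NC(=O)c3ccc([N+](=O)[O-])cc3)cc2s1`, gives in a functional assay on MCF7 cells (Homo sapiens) for cytotoxicity, read by MTT assay, with a stated time of 48 h (on this read-out higher numbers stand for weaker inhibition and lower numbers for stronger inhibition), a value of > 100000 nM, which is a limit of the assay and not a number. Compound 2, of structure `CNC(=O)CSc1nc2ccc(NC(=O)c3ccccc3)cc2s1`, gives in this assay a value of 34400 nM. Compound 3, of structure `O=C(CSc1nc2ccc(NC(=O)c3ccccc3)cc2s1)NCc1ccc(Cl)cc1`, gives in this assay a value of 33700 nM. The step from compound 1 to compound 2 is an at least 2.9-fold lower number from compound 1 to compound 2 (0.46 log units; beyond the scatter), a step that can only be bounded because of the limit of > 100000 nM in this assay, at which 1 of the 3 values shown sits. The step from compound 2 to compound 3 is a 1.0-fold lower number from compound 2 to compound 3 (0.01 log units; within the scatter). Among the two numbers shown, compound 2 holds the highest, with compound 3 close by it within the scatter.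

Compound 4, of structure `CNC(=O)CSc1nc2ccc(NC(C)=O)cc2s1`, has not yet been measured. It differs from compound 2 in this way: methyl in place of phenyl on a carbonyl carbon. Among the measured compounds shown here, no measured step alters the benzoyl group itself in this manner. The step from compound 1 to compound 2 shows that a change on the phenyl of that benzoyl can move the number beyond the scatter, while the step from compound 2 to compound 3 shows the amide-type nitrogen side tolerating a large change without effect. For compound 4 the author therefore expects a step of a 1.6-fold higher number from compound 2 to compound 4 (0.20 log units; within the scatter), a somewhat weaker inhibition, and estimates for compound 4 in this assay a value of 55000 nM, between 20000 nM and 150000 nM.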

Compound 4, half-maximal inhibitory concentration: > 100000 nM
Compound 4 gave a limit, no number (the forecaster's own chance of this, stated with the estimate: 25%); middle value at least 1.8-fold (0.25 log units) from the limit.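

On the carbonyl carbon, the phenyl of compound 2 turns out to matter: methyl in its place gives an at least 2.9-fold higher number from compound 2 to compound 4 (0.46 log units; beyond the scatter), a weaker inhibition in this assay. The earlier compounds had shown only that a nitro group on this phenyl could move the number, whereas here the ring itself leaves, and both changes give a weaker inhibition than compound 2 shows. Compound 1 and compound 4 each stand at a limit of the assay and not at a number, so the step above is only bounded and the step from compound 1 to compound 4 cannot be read: the limit of > 100000 nM in this assay, at which 2 of the 4 values shown sit.

As far as these compounds go, it stays open what an ethyl or a cyclohexyl group on this carbonyl carbon would give, and so whether the aromatic ring itself counts or any larger group would serve. From the compounds shown here alone, it also stays open whether the 4-chlorophenyl group of compound 3, whose step from compound 2 lies within the scatter in the benzoyl series, would likewise leave the number unmoved on the acetyl compound.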